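The source may report more compounds than this note shows. Statements on the series, on what has been measured and on what is new or still open speak of the compounds shown alone.

Compound 3 `C=CCN(C)C(=O)c1ccc(C(CC)(CC)c2ccc(OCC(O)C(C)(C)C)c(C)c2)n1CC` shares its core with compound 1 `C#CCNC(=O)c1ccc(C(CC)(CC)c2ccc(OCC(O)C(C)(C)C)c(C)c2)n1CC` and compound 2 `CCn1c(C(=O)N(C)CCC#N)ccc1C(CC)(CC)c1ccc(OCC(O)C(C)(C)C)c(C)c1` and differs from them only in the group on the carbonyl carbon. In a functional assay on HepG2 cells (Homo sapiens), read by MTT assay, with a stated time of 48 h (on this read-out higher numbers stand for weaker inhibition and lower numbers for stronger inhibition), compound 1 gives > 50000 nM as a limit of the assay and not as a number. Compound 2 gives > 50000 nM as a limit too. Compound 3 gives > 50000 nM as a limit as well. All three therefore stand at the limit of > 50000 nM in this assay, at which 3 of the 3 values shown sit, with no number among them.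

Compound 4 `CCn1c(C(=O)Oc2ccc(CCO)cc2)ccc1C(CC)(CC)c1ccc(OCC(O)C(C)(C)C)c(C)c1` changes that same place, with a group of 10 heavy atoms (8 carbon, 2 oxygen; one six-membered aromatic ring of carbon only) in place of a group of 5 heavy atoms (4 carbon, 1 nitrogen; no ring), on a carbonyl carbon as the counted difference, and so brings in a six-membered aromatic ring of carbon only where the allyl(methyl)amino of compound 3 has no ring. Among the compounds with values here, the measured steps bearing on this are a step that the two limits leave unreadable from compound 1 to compound 2 and a step that the two limits leave unreadable from compound 1 to compound 3 and also a step that the two limits leave unreadable from compound 2 to compound 3 as the only exchanges seen in this group, and none of them has a readable size or brings in a ring. No step beyond the scatter can therefore be argued for in this assay and no direction is expected. The estimate means a number no higher from compound 3 to compound 4 (the limit leaves the size open) as the expected step on this thin evidence. Compound 4 is expected at 50000 nM within an estimated range from 15000 nM to 120000 nM in the same read-out.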

Compound 4, half-maximal inhibitory concentration: > 50000 nM
Compound 4 ended at the assay's limit; the forecaster's own chance of this, stated with the estimate: 75%; the middle value lies on the limit itself.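

No new step can be read between compound 4 and compound 1, compound 2 or compound 3, since all four stand at a limit of the assay and not at a number: the limit of > 50000 nM in this assay, at which 4 of the 4 values shown sit.

The compounds shown leave open whether any group on the carbonyl carbon of the shared core would give a readable value in this assay.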